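Replacing an acyl group with furan-2-yl on oxygen

This account rests on a few compounds, and the source may have more. Where it says the series, first, only, none or still open, it means among the compounds named here.

In a functional assay on HeLa cells (Homo sapiens) for cytotoxicity (a higher number here means a weaker inhibitor, a lower number a stronger inhibitor), compound 1 (`C/C=C/C(=O)OC1=CC(=O)c2ccccc2C1=O`) gives 37900 nM. Compound 3 (`CC(=O)Oc1ccc2c(c1)C(=O)C=CC2=O`) gives 27700 nM, within the scatter of compound 1. Compound 2 (`Cc1ccc(S(=O)(=O)OC2=CC(=O)c3ccccc3C2=O)cc1`) gives 12200 nM, a number lower than that of compound 1 by more than the scatter. Compound 4 (`O=C1C=C(Oc2ccco2)C(=O)c2ccccc21`) remains unmeasured. In it, furan-2-yl takes the place of (prop-1-en-1-yl)carbonyl on an oxygen on an unsaturated carbon (furan-2-yl in place of (prop-1-en-1-yl)carbonyl on an oxygen on an unsaturated carbon). Among the compounds with values here, no measured pair shows this change, so the expectation in this assay is only a small move towards a lower number, not clearly beyond the scatter. The estimated step is a 1.7-fold lower number from compound 1 to compound 4 (0.24 log units; within the scatter). For compound 4 the expected value is 22000 nM, with an estimated range of 8000 nM to 55000 nM.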

Compound 4, half-maximal inhibitory concentration: 37000 nM
Estimate against measurement, compound 4: 1.7-fold (0.23 log units) below, within the range that was stated.
By their numbers in this assay, from the lowest: compound 2; then compounds 3, 4 and 1 (each within the scatter of the next).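

The exchange gives a 1.0-fold lower number from compound 1 to compound 4 (0.01 log units; within the scatter) in this assay and so shows that, on this oxygen on an unsaturated carbon, furan-2-yl can stand in place of (prop-1-en-1-yl)carbonyl without a move beyond the scatter. Within the data shown here, this is the first one-place step read at this position, and in this pair the carbonyl of the leaving group is not needed to hold the number. Nothing available explains this match. From the compounds shown here alone, whether a longer chain, an amine or a carboxylic acid on this oxygen would hold the number remains open. So does whether furan-2-yl would do the same on the core of compound 3.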